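From 1-benzofuran-2-yl to ethynyl: an expected small step

The source may report more compounds than this note shows. Statements on the series, on what has been measured and on what is new or still open speak of the compounds shown alone.

Measured so far in an ADME assay on MRC5 cells (Homo sapiens), read by MTT assay, with a stated time of 72 h; on this read-out lower numbers stand for stronger inhibition and higher numbers for weaker inhibition
- compound 1 `CNc1ncnc2c1c(-c1ccco1)cn2[C@@H]1O[C@H](CO)[C@@H](O)[C@H]1O` gives 90800 nM
- compound 2 `CNc1ncnc2c1c(-c1ccsc1)cn2[C@@H]1O[C@H](CO)[C@@H](O)[C@H]1O` gives > 100000 nM (a limit of the assay, not a number)
- compound 3 `CNc1ncnc2c1c(-c1cc3ccccc3o1)cn2[C@@H]1O[C@H](CO)[C@@H](O)[C@H]1O` gives 75300 nM

Only compound 1 and compound 3 give true numbers, and these lie within the scatter of each other (a 1.2-fold lower number from compound 1 to compound 3 (0.08 log units; within the scatter)). Compound 4 `C#Cc1cn([C@@H]2O[C@H](CO)[C@@H](O)[C@H]2O)c2ncnc(NC)c12` carries ethynyl in place of 1-benzofuran-2-yl on an aromatic carbon and has not yet been measured. Three measured steps exchange one aromatic group for another on an aromatic carbon: a 1.2-fold lower number from compound 1 to compound 3 (0.08 log units; within the scatter), an at least 1.1-fold higher number from compound 1 to compound 2 (0.04 log units; that floor lies within the scatter) and an at least 1.3-fold lower number from compound 2 to compound 3 (0.12 log units; that floor lies within the scatter). None of them shows a change beyond the scatter, but none replaces a ring-bearing group with one that has no ring, so they offer only a loose guide. The estimated step is therefore a 1.1-fold lower number from compound 3 to compound 4 (0.03 log units; within the scatter) and no change beyond the scatter is expected. For compound 4 the expected value is 70000 nM in this assay as a central estimate. The estimated range for compound 4 runs from 15000 nM to 100000 nM as a deliberately wide span.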

Compound 4, half-maximal inhibitory concentration: > 100000 nM
Compound 4 ended at the assay's limit; the forecaster's own chance of this, stated with the estimate: 30%; at least 1.4-fold (0.15 log units) between middle value and limit.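

In this assay the result for compound 4 is a limit of the assay, not a number, so its steps are only floors. With ethynyl, which has no ring, in place of the ring-bearing groups on this aromatic carbon, the readable steps are an at least 1.3-fold higher number from compound 3 to compound 4 (0.12 log units; that floor lies within the scatter) and an at least 1.1-fold higher number from compound 1 to compound 4 (0.04 log units; that floor lies within the scatter) and show no stronger inhibition, while the step between compound 2 and compound 4 cannot be read, as both values are limits. Neither the aromatic groups nor this small ring-free group moves the number beyond the scatter, and the readings now crowd against a ceiling: the limit of > 100000 nM in this assay, at which 2 of the 4 values shown sit.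

On these data alone, how far compound 4 lies past its limit stays open. So does whether an amine, a carboxylic acid or a longer chain on this aromatic carbon would shift the number beyond the scatter.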